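Swapping the Fused Bicyclic Group for a Small Triazole

The source may report more compounds than this note shows. Statements on the series, on what has been measured and on what is new or still open speak of the compounds shown alone.

Three compounds share a core carrying an acetamide arm; the group on that arm differs. Compound 1 `C[C@H]1CN(c2scnc2-c2nc3ccccc3[nH]2)CCN1C(=O)Cn1cnc2cccnc21` has a different core and gives 8030 nM in a functional assay on U2OS cells for antagonist activity at C-X-C chemokine receptor type 3 (Homo sapiens), read by beta-arrestin recruitment; a lower number here means a stronger inhibitor, a higher number a weaker inhibitor. Compound 2 `CCOc1ncc(-c2nc(C(F)(F)F)sc2N2CCN(C(=O)Cn3ncc4cccnc43)[C@H](C)C2)cn1` gives 55 nM in this assay. Compound 3 `CCOc1ncc(-c2nc(C(F)(F)F)sc2N2CCN(C(=O)Cn3c(=O)oc4ccccc43)[C@H](C)C2)cn1` gives 99 nM, the second highest of the three numbers: its nearest neighbour is compound 2, while compound 1 lies far above it. Among the measured compounds shown here, the only single-point step among the measured compounds, a 1.8-fold higher number from compound 2 to compound 3 (0.26 log units; within the scatter), replaced one fused bicyclic group with another on the same position and changed little. Compound 1 differs from the others in more than one place, so its value cannot be tied to the arm alone.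

Compound 4 `CCOc1ncc(-c2nc(C(F)(F)F)sc2N2CCN(C(=O)Cn3nc(C)nc3C)[C@H](C)C2)cn1` carries a much smaller group on that position: a group of 7 heavy atoms (4 carbon, 3 nitrogen; one five-membered aromatic ring with 3 hetero atoms) in place of a group of 10 heavy atoms (7 carbon, 1 nitrogen, 2 oxygen; one five-membered aromatic ring with 2 hetero atoms, one six-membered aromatic ring of carbon only), on a saturated chain carbon bound to a carbonyl carbon. For the measured compounds named here, no measured step shrinks a fused bicyclic group down to a single small ring, so the expectation rests on the tolerance seen in this assay between compound 2 and compound 3. A modest weakening is expected, so the step of a 2.2-fold higher number from compound 3 to compound 4 (0.35 log units; beyond the scatter) is estimated to lie only slightly beyond the scatter. For compound 4 the estimated value is 220 nM, with a range from 60 nM to 800 nM.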

Compound 4, half-maximal inhibitory concentration: 173 nM
The estimate for compound 4 lay 1.3-fold (0.10 log units) above the measured number; the measured number falls inside the stated range.
By their numbers in this assay, from the lowest: compounds 2, 3 and 4 (each within the scatter of the next, the first and the last beyond it); then compound 1.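

In this assay, the place on a saturated chain carbon bound to a carbonyl carbon turns out to accept a single small ring. Replacing the fused bicyclic group of compound 3 with 3,5-dimethyl-1H-1,2,4-triazol-1-yl gives a 1.7-fold higher number from compound 3 to compound 4 (0.24 log units; within the scatter), so on this evidence a six-membered aromatic ring in this group is not required to stay within the scatter of compound 3. Among the compounds shown here, the comparison with the other fused bicyclic group is less forgiving: the change gives a 3.1-fold higher number from compound 2 to compound 4 (0.50 log units; beyond the scatter), a modest weakening and the only step at this place that lies beyond the scatter, while compound 3 stays within the scatter of both compound 2 and compound 4.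

The compounds shown leave open whether the two methyl groups on the triazole matter, and whether a group of another kind on this arm, such as an open-chain amine, a carboxylic acid or a longer alkyl chain, would hold the number in the same range. Nothing measured here accounts for the size of these steps.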